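Ethoxy for Methoxy(methyl)amino on the Carbonyl of Compound 2

The compounds below may be only part of what the source reports. "The series", "measured", "known", "first", "only" and "open" are said of these compounds alone.

Measured compounds:
Compound 1 `CCOC(=O)C[C@H]1[C@@H](O[Si](C)(C)C(C)(C)C)[C@H](n2cnc3c(NC(=O)Nc4ccccc4)ncnc32)O[C@@H]1COC(=O)NC` gives 3.97 nM in this assay.
Compound 2 `CNC(=O)NC[C@H]1O[C@@H](n2cnc3c(NC(=O)Nc4ccccc4)ncnc32)[C@H](O[Si](C)(C)C(C)(C)C)[C@@H]1CC(=O)N(C)OC` gives 5.37 nM.

Both values come from a functional assay on HT-29 cells (Homo sapiens) for antiproliferative activity (on this read-out higher numbers stand for weaker inhibition of growth and lower numbers for stronger inhibition of growth), and on that read-out compound 2 gives the higher of the two numbers shown here, with compound 1 its nearest neighbour; the gap between the two lies within the scatter of the method, so nothing separates them in rank.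

Compound 3 `CCOC(=O)C[C@H]1[C@@H](O[Si](C)(C)C(C)(C)C)[C@H](n2cnc3c(NC(=O)Nc4ccccc4)ncnc32)O[C@@H]1CNC(=O)NC` has not been measured. It differs from compound 2 in one place (ethoxy in place of methoxy(methyl)amino on a carbonyl carbon). The rest of the structure, including the shared core, the silyl ether and the urea groups, is unchanged. Within the data shown here, the two measured compounds give no step of this kind, so no measured guide to its size exists; the leaving group and the entering group are of similar size and each carries one hydrogen-bond acceptor, and a step no larger than the scatter is expected in this assay, in no set direction.

The value of compound 3 is therefore expected to lie close to that of compound 2, at 4.5 nM with a range of 2.2 nM to 9.5 nM, which means an expected step of a 1.2-fold lower number from compound 2 to compound 3 (0.08 log units; within the scatter).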

Compound 3, concentration for 50% growth inhibition: 4.2 nM
Compound 3: middle estimate off by 1.1-fold (0.03 log units), on the high side, within the range that was stated.
By their numbers in this assay, from the lowest: compounds 1, 3 and 2 (each within the scatter of the next).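

In this assay, the exchange of methoxy(methyl)amino for ethoxy on a carbonyl carbon, whose other neighbour is a saturated chain carbon, now has a measured size (a 1.3-fold lower number from compound 2 to compound 3 (0.11 log units; within the scatter)), so these two groups cannot be told apart at this position on this read-out. Compound 3 also gives a single-place comparison with compound 1, with (methylcarbamoyl)amino in place of (methylcarbamoyl)oxy on a saturated chain carbon bound to a saturated ring carbon (a 1.1-fold higher number from compound 1 to compound 3 (0.02 log units; within the scatter)), and this exchange likewise leaves the two compounds unseparated. Nothing in the data at hand bears on what lies behind these two results.

From the compounds shown here alone, the three compounds cover only ethoxy and methoxy(methyl)amino on the carbonyl carbon, so it remains open whether a free carboxylic acid, a primary amide or a longer alkoxy chain at that place would also stay within the scatter. The silyl ether and the phenyl urea are the same in all three compounds, which leaves open how the number would respond if a free hydroxyl replaced the silyl ether or an amine replaced the phenyl urea.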